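A few compounds are considered here, and "the series" means these few. Any claim that something is new, unique, unknown or untested is made for them only; others in the source may bear on it.

Series notes. Compound 1 `O=C(Nc1cccc(-c2oc3cc(-c4ccc(F)cc4)ccc3c(=O)c2O)c1)c1ccc(F)cc1` gives 8590 nM in a functional assay on MCF7 cells (Homo sapiens) for antiproliferative activity, read by CCK-8 assay, with a stated time of 72 h; on this read-out higher numbers stand for weaker inhibition and lower numbers for stronger inhibition. Compound 2 `O=C(Nc1cccc(-c2oc3cc(-c4ccc(F)cc4)ccc3c(=O)c2O)c1)c1ccc(C(F)(F)F)cc1` gives 32600 nM in this assay, and compound 3 `O=C(Nc1cccc(-c2oc3cc(-c4ccc(F)cc4)ccc3c(=O)c2O)c1)c1ccc(Br)cc1` gives 24000 nM. Compound 2 holds the highest of the three numbers, though compound 3 sits within the scatter of it and only compound 1 lies beyond. The step to compound 4 `O=C(Nc1cccc(-c2oc3cc(-c4ccc(F)cc4)ccc3c(=O)c2O)c1)c1ccc([N+](=O)[O-])cc1` is nitro in place of trifluoromethyl on an aromatic carbon. Within the data shown here, no measured step introduces a nitro group; the steps that bear on it are a 3.8-fold higher number from compound 1 to compound 2 (0.58 log units; beyond the scatter) and a 2.8-fold higher number from compound 1 to compound 3 (0.45 log units; beyond the scatter), both raising the number when fluoro is replaced, while a 1.4-fold lower number from compound 2 to compound 3 (0.13 log units; within the scatter) keeps bromo and trifluoromethyl close. For compound 4 the expected step is a 1.5-fold lower number from compound 2 to compound 4 (0.17 log units; within the scatter), with no direction confidently beyond the scatter. Compound 4 is therefore estimated at 22000 nM, range 7000 nM to 65000 nM.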

Compound 4, half-maximal inhibitory concentration: 3970 nM
Compound 4: middle estimate off by 5.5-fold (0.74 log units), on the high side; measured number outside the range, below it.
By their numbers in this assay, from the lowest: compound 4; then compound 1; then compounds 3 and 2 (each within the scatter of the next).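

At this position, replacing fluoro need not raise the number: nitro gives a 2.2-fold lower number from compound 1 to compound 4 (0.34 log units; beyond the scatter), the only change shown that moves below compound 1. The gap to the other two groups is wider, with an 8.2-fold lower number from compound 2 to compound 4 (0.91 log units; beyond the scatter) and a 6.0-fold lower number from compound 3 to compound 4 (0.78 log units; beyond the scatter), so nitro stands apart from trifluoromethyl and bromo beyond the scatter. No measurement available here accounts for this separation. Going by these compounds, whether an amine, a nitrile or a carboxylic acid on this aromatic carbon would track nitro stays open. So does whether this order holds in other cell lines.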